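Swapping the Chlorophenyl Pattern in a Piperazine Amide Series

This account rests on a few compounds, and the source may have more. Where it says the series, first, only, none or still open, it means among the compounds named here.

Compound 1 `CC1(c2ccccc2)CC(=O)N(CC(=O)N2CCN(c3ccccc3Cl)CC2)C1=O` is the point of reference here. Among the compounds with values here, in a functional assay on the whole organism (strain CD-1) with Mus musculus as the target, with a stated time of 2 h (a higher number here means that more compound is needed for the effect, a lower number that less compound is needed), compound 1 gives 100 mg/kg, and that is the only number this set offers. Within the data shown here, compound 2 `CC1(c2ccccc2)CC(=O)N(CC(=O)N2CCN(c3cccc(C(F)(F)F)c3)CC2)C1=O` was reported in this assay as "not active" (no number reported), and compound 3 `CC1(c2ccccc2)CC(=O)N(CC(=O)N2CCN(c3ccc(F)cc3)CC2)C1=O` was likewise reported in this assay as "not active" (no number reported); neither result comes with a number, so no step between measured compounds can be sized.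

Compound 4 `CC1(c2ccccc2)CC(=O)N(CC(=O)N2CCN(c3ccc(Cl)cc3)CC2)C1=O` differs from compound 1 in one place: 4-chlorophenyl in place of 2-chlorophenyl on an amine nitrogen in a ring. Compound 1 carries a 2-chlorophenyl on the amine nitrogen in the ring, and compound 4 carries a 4-chlorophenyl there. Among the measured compounds shown here, compounds 2 and 3 both lack an effect at the doses tried, which leaves compound 1 as the lone active reference and gives no measured step on which to lean.

Compound 4 is therefore expected to need a somewhat higher dose than compound 1, with an expected step of a 2.0-fold higher number from compound 1 to compound 4 (0.30 log units; within the scatter), and a fair chance that only an absence of effect is reported. The estimated value for compound 4 in this assay is 200 mg/kg, within a range from 100 mg/kg to 400 mg/kg.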

Compound 4, minimum effective dose: 300 mg/kg
The estimate for compound 4 lay 1.5-fold (0.18 log units) below the measured number; the measured number falls inside the stated range.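

Moving the chlorine is not a neutral change in this assay: 4-chlorophenyl in place of 2-chlorophenyl on the amine nitrogen in the ring gives a 3.0-fold higher number from compound 1 to compound 4 (0.48 log units; beyond the scatter), the first step in this set that can be sized, with the same atoms joined differently. A chlorophenyl at this place gives a number with either pattern, whereas compound 3, with fluorine in place of the chlorine of compound 4, was reported only as not active, so the steps that involve compounds without a number cannot be read. Nothing available here bears on why the location of the chlorine matters.

As far as these compounds go, it remains open whether a bromine or a methoxy group in place of the chlorine of compound 1 would preserve the effect. How a plain phenyl on the same nitrogen would compare is also unresolved.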